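The compounds below may be only part of what the source reports. "The series", "measured", "known", "first", "only" and "open" are said of these compounds alone.

Three compounds share one core and differ only in the group carried on a saturated chain carbon bound to a nitrogen on an aromatic ring. In an assay for inhibition of Indoleamine 2,3-dioxygenase 1 (Homo sapiens), with stated times of 10 min and 60 min, tested at 10 uM (a lower number here means a weaker effect, a higher number a stronger effect of the compound at the concentration tested), compound 1 `Oc1ccc(CNc2cc(C(F)(F)F)cc3[nH]ncc23)cc1` gives 37%, compound 2 `FC(F)(F)c1cc(NC[C@@H]2CCCCN2)c2cn[nH]c2c1` gives 32%, and compound 3 `Nc1cccc(CNc2cc(C(F)(F)F)cc3[nH]ncc23)c1` gives 24%. Among the compounds with values here, compound 3 has the lowest of the three numbers, but its distance to compound 2 lies within the scatter; only the step of a number 13 percentage points lower from compound 1 to compound 3 (beyond the scatter) goes beyond it, while the steps of a number 5 percentage points lower from compound 1 to compound 2 (within the scatter) and a number 8 percentage points lower from compound 2 to compound 3 (within the scatter) stay within the scatter.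

Compound 4 `FC(F)(F)c1cc(NCc2cccc(Br)c2)c2cn[nH]c2c1` has not yet been measured. It differs from compound 3 in one place: bromo in place of amino on an aromatic carbon. Within the data shown here, no measured step exchanges one substituent for another on the 3-aminophenyl group, so nothing bears on this change directly; the only steps that involve that group are the ones that introduced it, a number 13 percentage points lower from compound 1 to compound 3 (beyond the scatter) and a number 8 percentage points lower from compound 2 to compound 3 (within the scatter), and they point in no clear direction for its removal. Compound 4 is therefore expected to show a step of a number 6 percentage points higher from compound 3 to compound 4 (within the scatter) that stays within the scatter. The estimate for compound 4 in this assay is 30%, with a range from 15% to 50%.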

Compound 4, a percentage reported as inhibition, at one concentration (the size of the read-out at that concentration, not a potency): 23%
Estimate against measurement, compound 4: 7 percentage points above, and the stated range covers the measured number.
By their numbers in this assay, from the lowest: compounds 4, 3, 2 and 1 (each within the scatter of the next, the first and the last beyond it).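

In this assay, within the data shown here, this is the first direct exchange on this aromatic carbon of the phenyl ring: bromo in place of amino gives a number 1 percentage points lower from compound 3 to compound 4 (within the scatter) and so shows no change that can be told from the scatter, even though amino counts a hydrogen-bond donor and acceptor and bromo counts neither. Compared across the chain carbon, the 3-bromophenyl group gives a number 9 percentage points lower from compound 2 to compound 4 (within the scatter) against the piperidin-2-yl group and a number 14 percentage points lower from compound 1 to compound 4 (beyond the scatter) against the 4-hydroxyphenyl group, so it stands relative to those two groups much as the 3-aminophenyl group did. Nothing at hand explains these numbers, and the amino and bromo results alone give no reason for their closeness.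

Still open, as far as these compounds go, is whether another group on this aromatic carbon, such as a carboxylic acid, a nitrile or a methoxy group, would move the number beyond the scatter. Also open, from the compounds shown here alone, is whether a 3-hydroxyphenyl or 4-bromophenyl group would separate the effect of the substituent itself from the effect of its place on the ring, since the 4-hydroxyphenyl group differs from the other two phenyl groups in both respects.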